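A few compounds are considered here, and "the series" means these few. Any claim that something is new, unique, unknown or untested is made for them only; others in the source may bear on it.

In a functional assay on HCT-116 cells (Homo sapiens) for inhibition, read by CCK-8 assay, with a stated time of 48 h (a higher number here means a weaker inhibitor, a lower number a stronger inhibitor), compound 1 `COc1cc(-c2ccnc3cc(-c4ccc(Cl)cc4)nn23)cc(OC)c1OC` gives 3340 nM and compound 2 `COc1cc(-c2ccnc3cc(-c4ccc(C)cc4)nn23)cc(OC)c1OC` gives 48 nM on the same core. Compound 3 `COc1cc(-c2ccnc3cc(-c4cn(C)c5ccccc45)nn23)cc(OC)c1OC` sits between them with 762 nM as its value. Compound 4 `COc1ccc(-c2cc3nccc(-c4cc(OC)c(OC)c(OC)c4)n3n2)cc1F` alters compound 3 in one place, as 3-fluoro-4-methoxyphenyl in place of 1-methyl-1H-indol-3-yl on an aromatic carbon shows. The entering 3-fluoro-4-methoxyphenyl is again a phenyl ring, so two steps bear on it: a 4.4-fold lower number from compound 1 to compound 3 (0.64 log units; beyond the scatter) on one side and a 16-fold higher number from compound 2 to compound 3 (1.20 log units; beyond the scatter) on the other. Yet one swap on such a ring gave a 70-fold lower number from compound 1 to compound 2 (1.84 log units; beyond the scatter) as its size, so phenyl groups can land far apart. A modest drop is therefore expected, an estimated 2.5-fold lower number from compound 3 to compound 4 (0.40 log units; beyond the scatter) in size, though the opposite direction remains possible. For compound 4 the estimate is 300 nM with an expected range from 40 nM to 2500 nM as the likely span.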

Compound 4, half-maximal inhibitory concentration: 2840 nM
For compound 4 the middle estimate is 9.5-fold (0.98 log units) below the measured one; the measured number lies above the stated range.
By their numbers in this assay, from the lowest: compound 2; then compound 3; then compounds 4 and 1 (each within the scatter of the next).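

Putting a phenyl ring back at this position does not by itself restore a low number in this assay: 3-fluoro-4-methoxyphenyl gives a 3.7-fold higher number from compound 3 to compound 4 (0.57 log units; beyond the scatter) and a 59-fold higher number from compound 2 to compound 4 (1.77 log units; beyond the scatter) and, against 4-chlorophenyl, a 1.2-fold lower number from compound 1 to compound 4 (0.07 log units; within the scatter) within the scatter. Among these three compounds with a phenyl ring, then, only the 4-methylphenyl of compound 2 stands apart, so the groups on the ring matter, not the ring alone. No evidence here explains these gaps.

The fluoro and methoxy groups enter together, so their separate contributions cannot be told apart. From the compounds shown here alone, how an amine, a carboxylic acid or a longer chain on this phenyl ring would behave remains open.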